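Ring closure of a pentyl chain: cyclohexyl at the amine

The source may report more compounds than this note shows. Statements on the series, on what has been measured and on what is new or still open speak of the compounds shown alone.

Measured so far:
Compound 1 `CCCCCNc1oc2c(C)ncc(CO)c2c1Nc1ccccn1` gives 5810 nM.
Compound 2 `CCOC(=O)CNc1oc2c(C)ncc(CO)c2c1Nc1ccccn1` is reported as "not active" (no number reported).
Compound 3 `Cc1ncc(CO)c2c(Nc3ccccn3)c(NC(C)(C)CC(C)(C)C)oc12` is reported as "not active" (no number reported).

These three compounds share one core and differ only in the group on the ring nitrogen. They were tested in a functional assay on HEK293 cells for agonist activity at Toll-like receptor 8 (Homo sapiens), read by reporter gene assay; on this read-out higher numbers stand for an effect only at larger amounts of compound and lower numbers for an effect already at smaller amounts. Among the measured compounds shown here, compound 1 is the only one with a number; compound 2 and compound 3 gave no measurable effect, so compound 1 stands alone as the reference point.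

Compound 4 `Cc1ncc(CO)c2c(Nc3ccccn3)c(NC3CCCCC3)oc12` has not been measured. Its difference from compound 1 is cyclohexyl in place of pentyl on a nitrogen on an aromatic ring. The chain is folded into a ring of nearly the same size, whereas the inactive compound 3 carries a much more branched group and compound 2 an ester-bearing one. A modest step is expected, most likely within the scatter or slightly weaker; the estimated step is a 1.2-fold higher number from compound 1 to compound 4 (0.08 log units; within the scatter). Compound 4 is expected to give about 7000 nM, with a range from 2500 nM to 25000 nM.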

Compound 4, half-maximal effective concentration: 6930 nM
Compound 4: the middle estimate sits 1.0-fold (0.00 log units) above what was measured, and the stated range covers the measured number.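

In this assay putting cyclohexyl in place of pentyl on this nitrogen gives a 1.2-fold higher number from compound 1 to compound 4 (0.08 log units; within the scatter) and so no change that can be told from the usual scatter. This shows that the group here need not be an open chain: a six-membered carbon ring also gives a measurable number, whereas compound 2 and compound 3 gave none. No measured evidence is available to explain why the chain and the ring match so closely.

Still open, on these data alone, is whether a longer chain such as octyl, a smaller ring such as cyclopentyl, or a benzyl group on this nitrogen would give a lower number than compound 1 and compound 4. It is also unclear whether a pentyl chain carrying an amine or a carboxylic acid would give any measurable effect.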